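The compounds below may be only part of what the source reports. "The series", "measured", "known", "first", "only" and "open" are said of these compounds alone.

Compound 1 `O=C(Nc1ccc(Oc2ccnc3[nH]ccc23)cc1)c1nn(-c2ccc(Cl)cc2)ccc1=O` gives 10600 nM in a functional assay on MCF7 cells (Homo sapiens) for cytotoxicity, read by MTT assay, with a stated time of 72 h; a higher number here means a weaker inhibitor, a lower number a stronger inhibitor.
Compound 2 `O=C(Nc1ccc(Oc2ccnc3[nH]ccc23)c(F)c1)c1nn(-c2ccc(Cl)cc2)ccc1=O` reaches only the assay limit, > 60000 nM, in this assay.

Compound 2 therefore stands at the limit of > 60000 nM in this assay, at which 1 of the 2 values shown sits, so its value is a limit and not a number. Going by the values given here, the one measured step, an at least 5.6-fold higher number from compound 1 to compound 2 (0.75 log units; beyond the scatter), carries the series from a number into that limit through a fluoro in place of hydrogen on an aromatic carbon.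

Compound 3 `O=C(Nc1ccc(Oc2ccnc3[nH]ccc23)c(F)c1)c1nn(-c2ccccc2)ccc1=O` differs from compound 2 by hydrogen in place of chloro on an aromatic carbon. No measured step involves the removal of a chloro, so the size and direction of this change in this assay cannot be read from the shown steps; the only step measured, an at least 5.6-fold higher number from compound 1 to compound 2 (0.75 log units; beyond the scatter), concerns a different substituent. Since compound 2 already sits at the limit, compound 3 is expected to stay weak, most likely again reported only as a limit. The estimate for compound 3 is 80000 nM, with a range from 20000 nM to 300000 nM. This corresponds to an expected step that the limit leaves unreadable from compound 2 to compound 3.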

Compound 3, half-maximal inhibitory concentration: 34900 nM
Estimate against measurement, compound 3: 2.3-fold (0.36 log units) above; the measured number falls inside the stated range.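

In this assay, compound 3 carries a measured number where compound 2 has only a limit, so this position on the ring, para to a large group, can be changed without the value staying at that limit. The 4-chlorophenyl to phenyl change gives an at least 1.7-fold lower number from compound 2 to compound 3 (0.23 log units; that floor lies within the scatter), which means the floor alone does not establish a real gain from removing the chloro. The true size of the step cannot be read because compound 2 has a limit and not a number: the limit of > 60000 nM in this assay, at which 1 of the 3 values shown sits.

As far as these compounds go, what the same change does without the fluoro remains open. So does how a methyl, a methoxy, a nitrile or an amine at this position would read in this assay.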